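The source may report more compounds than this note shows. Statements on the series, on what has been measured and on what is new or still open speak of the compounds shown alone.

Values in an ADME assay on the whole organism (plasma, Rattus norvegicus) for protein binding, using cassette dosing, at a dose of 1 mg/kg; a higher number here means a larger unbound share of the compound, a lower number a smaller unbound share:
- compound 1 `C[C@@H](Cn1c(=O)[nH]/c(=N\c2ccc(Oc3cncc(F)c3)cc2)n(Cc2ccc(Cl)cc2)c1=O)C(=O)O`: 0.02
- compound 2 `CC(C)Oc1ccc(Nc2nc(=O)n(CCO)c(=O)n2Cc2ccc(Cl)cc2)cc1Cl`: 0.001
- compound 3 `CC(C)Oc1ccc(Nc2nc(=O)n(CCCO)c(=O)n2Cc2ccc(Cl)cc2)cc1Cl`: 0.003

Compound 1 has the highest of the three values. Compound 4 `C[C@@H](Cn1c(=O)[nH]/c(=N\c2ccc(Oc3ccsn3)cc2)n(Cc2ccc(Cl)cc2)c1=O)C(=O)O` carries one change from compound 1: 1,2-thiazol-3-yl in place of 5-fluoropyridin-3-yl on an oxygen on an aromatic ring. This places 1,2-thiazol-3-yl in place of 5-fluoropyridin-3-yl on an oxygen on an aromatic ring. Going by the values given here, the only measured step, a 3.0-fold higher number from compound 2 to compound 3 (0.48 log units; beyond the scatter), is modest, but it is hydroxymethyl in place of hydroxy on a saturated chain carbon, so it does not touch this oxygen substituent. Among the compounds with values here, no measured step covers this change, so no shift beyond the scatter is expected in this assay. The expected step is a 1.3-fold higher number from compound 1 to compound 4 (0.10 log units; within the scatter). Compound 4 is estimated at 0.025, with an expected range of 0.01 to 0.06.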

Compound 4, unbound fraction: 0.012
Compound 4: the middle estimate sits 2.1-fold (0.32 log units) above what was measured, and the stated range covers the measured number.
By their numbers in this assay, from the lowest: compound 2; then compound 3; then compounds 4 and 1 (each within the scatter of the next).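

In this assay, going by these compounds alone, the oxygen substituent on the aromatic ring now has a reading: the exchange gives a 1.7-fold lower number from compound 1 to compound 4 (0.22 log units; within the scatter) and is the only step on this position. The unbound fraction therefore does not separate 1,2-thiazol-3-yl from 5-fluoropyridin-3-yl here, despite the change from a six-membered to a five-membered aromatic ring. Nothing available explains this result.

Still open, on these data alone, is whether a plain phenyl ring or a pyridine carrying an amine on this oxygen would give a step beyond the scatter. Also open, as far as these compounds go, is whether an amide in place of the carboxylic acid would do so.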